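The source may hold more compounds than are shown below. What is called first, only, known or untested is meant among the compounds shown, and "the series" means these compounds.

Measured compounds and values in a functional assay on the whole organism (strain Wistar albino) for inhibition, with Rattus norvegicus as the target, read by paw edema, with a stated time of 30 min, at a dose of 50 mg/kg by the oral route; on this read-out higher numbers stand for more inhibition at the one dose given (going by the name of the read-out) and lower numbers for less inhibition:

- compound 1, `NS(=O)(=O)c1ccc(N2N=C(c3ccc(F)cc3)CC2c2cn(-c3ccccc3)nc2-c2ccccc2)cc1`: 22%
- compound 2, `Cc1ccc(-c2nn(-c3ccccc3)cc2C2CC(c3ccccc3)=NN2c2ccc(S(N)(=O)=O)cc2)cc1`: 18%
- compound 3, `Cc1ccc(C2=NN(c3ccc(S(N)(=O)=O)cc3)C(c3cn(-c4ccccc4)nc3-c3ccc(C)cc3)C2)cc1`: 18%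

Compound 1 gives the highest of the three numbers in this assay, but the gaps to compound 2 and to compound 3 both lie within the scatter, so the three read as one level.

Going by the values given here, the only single-point step between measured compounds is no change at the digits printed from compound 2 to compound 3 (within the scatter), a methyl in place of hydrogen on an aromatic carbon: no change beyond the scatter. Among the compounds with values here, that is the one precedent for a small substituent added to an aromatic carbon.

The unmeasured compound is compound 4, `NS(=O)(=O)c1ccc(N2N=C(c3ccc(F)cc3)CC2c2cn(-c3ccccc3)nc2-c2ccc(F)cc2)cc1`. It differs from compound 1 as follows: fluoro in place of hydrogen on an aromatic carbon. Given that the step from compound 2 to compound 3 showed nothing beyond the scatter, the expectation for compound 4 in this assay is a step of about no change at the digits printed from compound 1 to compound 4 (within the scatter), that is no change beyond the scatter. Compound 4 is therefore estimated at 22%, with a range from 12% to 32%.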

Compound 4, a percentage reported as inhibition, in the whole organism at one dose (the size of the read-out at that dose, not a potency): 18%
Beside the measured number, compound 4's estimate is 4 percentage points above it, and the stated range covers the measured number.
By their numbers in this assay, from the lowest: compounds 2, 3, 4 and 1 (each within the scatter of the next).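

In this assay, the change from phenyl to 4-fluorophenyl gives a number 4 percentage points lower from compound 1 to compound 4 (within the scatter), so fluoro on this aromatic carbon, para to a large group, adds a second small substituent to the methyl precedent, no change at the digits printed from compound 2 to compound 3 (within the scatter). At this position, fluoro in place of hydrogen produces no step beyond the scatter at the one dose given, and the four compounds still read as one level. No measurement here bears on why the number stays level.

As far as these compounds go, it remains open whether a different group on this carbon, such as a methoxy, an amine or a carboxylic acid, would give a step beyond the scatter. From the compounds shown here alone, it is also open whether fluoro on another carbon of this ring would read the same.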